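From Amino to Methoxy on the Aryl Ketone

A few compounds are considered here, and "the series" means these few. Any claim that something is new, unique, unknown or untested is made for them only; others in the source may bear on it.

Compound 1 `COc1cc(-c2cc(/C=C/C(=O)c3ccc(N)cc3)[nH]n2)cc(OC)c1OC` gives -40% in a functional assay on SW-620 cells (Homo sapiens) for cytotoxicity, read by sulforhodamine B assay, with a stated time of 48 h, tested at 100 uM (on this read-out higher numbers stand for a weaker effect at the one concentration tested and lower numbers for a stronger effect), the highest of the three numbers measured. Compound 3 `COc1ccc(-c2cc(/C=C/C(=O)c3cc(OC)c(OC)c(OC)c3)[nH]n2)cc1OC` gives -43% in this assay, within the scatter of compound 1, while compound 2 `COc1ccc(-c2cc(/C=C/C(=O)c3ccc(N)cc3)[nH]n2)cc1OC` gives -53%. Among the compounds with values here, the only single-point step is a number 13 percentage points lower from compound 1 to compound 2 (beyond the scatter), and it concerns a different part of the molecule. Compound 4 `COc1ccc(C(=O)/C=C/c2cc(-c3cc(OC)c(OC)c(OC)c3)n[nH]2)cc1` differs from compound 1 by methoxy in place of amino on an aromatic carbon. Within the data shown here, no measured step touches this change; compound 2 keeps the amino group of compound 1 and compound 3 does not, and their values stand within the scatter of each other, so no shift beyond the scatter is expected. The step from compound 1 to compound 4 is expected to be no change at the digits printed from compound 1 to compound 4 (within the scatter). Compound 4 is therefore estimated at -40%, within the range -60% to -20%.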

Compound 4, a percentage reported as activity, at one concentration (the size of the read-out at that concentration, not a potency): -39%
Compound 4: middle estimate off by 1 percentage points, on the low side, and the stated range covers the measured number.
By their numbers in this assay, from the lowest: compounds 2, 3, 1 and 4 (each within the scatter of the next, the first and the last beyond it).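

In this assay, within the data shown here, the exchange of 4-aminophenyl for 4-methoxyphenyl gives a number 1 percentage points higher from compound 1 to compound 4 (within the scatter), the first direct reading at this position. In the setting of compound 1, the amino group and its hydrogen-bond donor can therefore be replaced by methoxy without a shift beyond the scatter. No available evidence explains this result. As far as these compounds go, it remains open whether a hydroxyl group, a dimethylamino group or a carboxylic acid at this position would leave the read-out equally unmoved. From the compounds shown here alone, it also remains open whether the same exchange would hold on the core of compound 2.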